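Swapping the ester group of compound 2

The source may report more compounds than this note shows. Statements on the series, on what has been measured and on what is new or still open speak of the compounds shown alone.

In an ADME assay on a cell-free system (plasma, Homo sapiens) for metabolic stability, read by LC-MS (a lower number here means that the compound disappears faster, a higher number that the compound lasts longer), compound 2 (`CC(C)OCCOC(=O)c1cccc(-c2cc(C(=O)Nc3ccncc3F)ccc2CN)c1`) gives 0.1 h, the lowest of the three numbers and beyond the scatter from both others: compound 3 (`CCCCCOC(=O)c1cccc(-c2cc(C(=O)Nc3ccncc3)ccc2CN)c1`) gives 0.967 h and compound 1 (`NCc1ccc(C(=O)Nc2ccncc2)cc1-c1cccc(C(=O)OCc2ccccc2)c1`) gives 1.07 h. Compound 4 (`NCc1ccc(C(=O)Nc2ccncc2F)cc1-c1cccc(C(=O)OC2CCCOC2)c1`) follows from compound 2 through (oxan-3-yl in place of 2-isopropoxyethyl on an oxygen next to a carbonyl group), so a six-membered non-aromatic ring enters where no ring stood. Within the data shown here, the only measured step that bears on this is a 1.1-fold lower number from compound 1 to compound 3 (0.04 log units; within the scatter), which also alters the group on that oxygen. Compounds 1 and 3 differ from compound 2 in more than that group, so their gap sets no size here. In this assay, the expected change is a slight rise, a 1.8-fold higher number from compound 2 to compound 4 (0.26 log units; within the scatter), not beyond the scatter. For compound 4 the estimate is 0.18 h, with an expected range of 0.06 h to 0.6 h.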

Compound 4, half-life: 0.3 h
Compound 4: middle estimate off by 1.7-fold (0.22 log units), on the low side; the range from low to high includes it.
By their numbers in this assay, from the lowest: compound 2; then compound 4; then compounds 3 and 1 (each within the scatter of the next).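

In this assay, the change shows a step beyond the scatter at this position, a 3.0-fold higher number from compound 2 to compound 4 (0.48 log units; beyond the scatter), whereas the earlier step on that oxygen, a 1.1-fold lower number from compound 1 to compound 3 (0.04 log units; within the scatter), stayed within it. Oxan-3-yl and 2-isopropoxyethyl have the same heavy-atom count and the same hydrogen-bond acceptor count, yet they differ in the six-membered non-aromatic ring. No evidence at hand explains the rise. On these data alone, whether a cyclohexyl group or a ring carrying an amine on the same oxygen would give a similar step remains open. So does whether the oxan-3-yl swap would give the same step on the core of compound 3.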